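Swapping Trifluoromethyl for Methyl on the Weakest Compound

The source may hold more compounds than are shown below. What is called first, only, known or untested is meant among the compounds shown, and "the series" means these compounds.

Compound 2 `O=C1NC(=O)C(Cc2ccc(Oc3cccc(C(F)(F)F)n3)cc2)S1` gives the highest number of the three measured compounds in a functional assay for agonist activity at Free fatty acid receptor 1 (Homo sapiens), read by FLIPR, in the presence of a further agent that is not named here; on this read-out higher numbers stand for an effect only at larger amounts of compound and lower numbers for an effect already at smaller amounts: in that assay compound 2 gives 1640 nM. Its nearest neighbour is compound 1 `Cc1cc(Oc2ccc(CC3SC(=O)NC3=O)cc2)nc(C(F)(F)F)c1`, which in this assay gives 688 nM, while compound 3 `Cc1cc(Oc2ncc(C(F)(F)F)cc2Cl)ccc1CC1SC(=O)NC1=O` stands far away, giving 10 nM in this assay. Among the measured compounds shown here, the only step between compounds that differ in a single place runs from compound 1 to compound 2, where a 2.4-fold higher number from compound 1 to compound 2 (0.38 log units; beyond the scatter).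

Compound 4 `Cc1cccc(Oc2ccc(CC3SC(=O)NC3=O)cc2)n1` has not yet been measured. It differs from compound 2 in one place: methyl in place of trifluoromethyl on an aromatic carbon. For the measured compounds named here, no measured step touches this position. Going by the values given here, the single measured step concerns a methyl on a different ring of the shared core, and it is only a loose guide: removing that methyl moved the number modestly, whereas here a methyl enters in exchange for trifluoromethyl, a change of another kind. With nothing directly comparable, the expected change from compound 2 to compound 4 is a 1.1-fold lower number from compound 2 to compound 4 (0.04 log units; within the scatter), which amounts to no step beyond the scatter. Compound 4 is therefore estimated at 1500 nM, with a range from 450 nM to 5000 nM.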

Compound 4, half-maximal effective concentration: 2620 nM
For compound 4 the middle estimate is 1.7-fold (0.24 log units) below the measured one; measured number inside the range.
By their numbers in this assay, from the lowest: compound 3; then compound 1; then compounds 2 and 4 (each within the scatter of the next).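

Compound 1 and compound 2 both carry trifluoromethyl on this aromatic carbon next to the ring nitrogen, so they could not show whether the position needs that particular group. In this assay, methyl in place of trifluoromethyl gives a 1.6-fold higher number from compound 2 to compound 4 (0.20 log units; within the scatter) and so, on this core, a group of 1 heavy atom takes the place of one with 4 heavy atoms, including all the fluorine, without a change that can be told apart from the scatter. Nothing measured here explains why the exchange leaves the number within the scatter.

The compounds shown leave open whether a group of another kind on this carbon, such as an amine, a carboxylic acid or a longer chain, would keep the number in this region or move it well beyond the scatter. They also leave open whether the same exchange would be just as quiet on the core of compound 1, which carries a further methyl on the same ring.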